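From furan-3-yl to cyclohexyl in a cell toxicity test

This account rests on a few compounds, and the source may have more. Where it says the series, first, only, none or still open, it means among the compounds named here.

Measured in an ADME assay on BHK-21 cells (Mesocricetus auratus) for cytotoxicity, read by MTT assay; on this read-out lower numbers stand for higher toxicity in this test and higher numbers for lower toxicity in this test:
- compound 1 `C/C(=N\NC(N)=S)c1ccc2[nH]c(-c3ccccc3)nc2c1`: 32000 nM
- compound 2 `COc1ccc(-c2nc3cc(/C(C)=N/NC(N)=S)ccc3[nH]2)cc1`: 13000 nM
- compound 3 `C/C(=N\NC(N)=S)c1ccc2[nH]c(-c3ccoc3)nc2c1`: > 100000 nM

Compound 3 has the highest reading of these three, and its value is a limit of the assay, not a number. Two measured steps set it apart, both beyond the scatter: an at least 3.1-fold higher number from compound 1 to compound 3 (0.49 log units; beyond the scatter), and an at least 7.6-fold higher number from compound 2 to compound 3 (0.88 log units; beyond the scatter).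

Compound 4 `C/C(=N\NC(N)=S)c1ccc2[nH]c(C3CCCCC3)nc2c1` changes one group, with cyclohexyl in place of furan-3-yl on an aromatic carbon. Among the measured compounds shown here, no measured step involves cyclohexyl. The closest guide is phenyl, also a six-membered ring, in compound 1 at 32000 nM. Adding methoxy to that ring gave only a modest shift: a 2.5-fold lower number from compound 1 to compound 2 (0.39 log units; beyond the scatter).

Compound 4 is therefore expected to lie nearer compound 1 than the limit reached by compound 3, which would undo much of an at least 3.1-fold higher number from compound 1 to compound 3 (0.49 log units; beyond the scatter). The expected change in this assay is a clear drop: an at least 3.3-fold lower number from compound 3 to compound 4 (0.52 log units; beyond the scatter). For compound 4 the estimated value is 30000 nM, with an expected range of 10000 nM to 90000 nM.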

Compound 4, half-maximal cytotoxic concentration: 24000 nM
Compound 4: the middle estimate sits 1.3-fold (0.10 log units) above what was measured; measured number inside the range.
By their numbers in this assay, from the lowest: compounds 2, 4 and 1 (each within the scatter of the next, the first and the last beyond it). At a limit, above all of these: compound 3.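

In this assay, the change to cyclohexyl gives an at least 4.1-fold lower number from compound 3 to compound 4 (0.61 log units; beyond the scatter), so the high reading of furan-3-yl does not carry over to this non-aromatic carbon ring at the position between two ring nitrogen atoms. The other two comparisons, a 1.3-fold lower number from compound 1 to compound 4 (0.12 log units; within the scatter) and a 1.8-fold higher number from compound 2 to compound 4 (0.27 log units; within the scatter), both stay within the scatter, so cyclohexyl cannot be told apart from phenyl or 4-methoxyphenyl here. Of the four compounds, only compound 3, the one with a hetero atom in this ring, reads at a limit and not at a number: the limit of > 100000 nM in this assay, at which 1 of the 4 values shown sits.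

Compound 3 differs from the others in both ring size and ring hetero atom, so the compounds shown do not separate the two. Cyclopentyl, a five-membered ring of carbon only, and thiophen-3-yl, with sulfur in place of the furan oxygen, would be informative next groups.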